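A few compounds are considered here, and "the series" means these few. Any claim that something is new, unique, unknown or untested is made for them only; others in the source may bear on it.

Series notes, ketone aryl ring variation on the shared core. Compound 1 `COc1ccc(C(=O)/C=C/c2cccc(OCc3ccccc3)c2)cc1` gives 19900 nM in a functional assay on ZR-75-1 cells (Homo sapiens) for cytotoxicity, read by MTT assay, with a stated time of 68 h; a higher number here means a weaker inhibitor, a lower number a stronger inhibitor. Compound 2 `O=C(/C=C/c1cccc(OCc2ccccc2)c1)c1ccc(Cl)cc1Cl` gives 9400 nM in this assay, and compound 3 `O=C(/C=C/c1cccc(OCc2ccccc2)c1)c1ccc([N+](=O)[O-])cc1` gives 37700 nM. Among these three numbers compound 3 stands highest: its nearest neighbour is compound 1, a gap within the scatter, while the step of a 4.0-fold higher number from compound 2 to compound 3 (0.60 log units; beyond the scatter) lies beyond it.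

Compound 4 `O=C(/C=C/c1cccc(OCc2ccccc2)c1)c1ccc(Cl)cc1` is not yet measured. It differs from compound 3 as follows: chloro in place of nitro on an aromatic carbon

Within the data shown here, two measured steps bear on this change. The step of a 1.9-fold higher number from compound 1 to compound 3 (0.28 log units; within the scatter) shows that the nitro group, set against methoxy, moves the number only within the scatter. The step of a 4.0-fold higher number from compound 2 to compound 3 (0.60 log units; beyond the scatter) shows a modest gain in the other direction when chloro substitution replaces the nitro group, though that step also carries a second chloro that compound 4 lacks, and the step of a 2.1-fold lower number from compound 1 to compound 2 (0.33 log units; beyond the scatter) is itself only modest. A chloro group para to a large group, without the second chloro, is therefore expected to lower the number, but by less than the full step seen with compound 2.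

For compound 4 the expected step is a 2.5-fold lower number from compound 3 to compound 4 (0.40 log units; beyond the scatter). Compound 4 is thus estimated at 15000 nM, with a range of 7000 nM to 35000 nM.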

Compound 4, half-maximal inhibitory concentration: 20000 nM
The estimate for compound 4 lay 1.3-fold (0.12 log units) below the measured number; low and high end bracket the measured number.
By their numbers in this assay, from the lowest: compound 2; then compounds 1, 4 and 3 (each within the scatter of the next).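

Working notes on the para place: the change from 4-nitrophenyl to 4-chlorophenyl, read alone in this assay, stays within the scatter (a 1.9-fold lower number from compound 3 to compound 4 (0.28 log units; within the scatter)), and the chloro in place of methoxy on the same aromatic carbon shows no readable separation either (a 1.0-fold higher number from compound 1 to compound 4 (0.00 log units; within the scatter)). A single chloro para to a large group therefore cannot be told apart from nitro or methoxy on these compounds, so the lower number expected for it finds no support here. Among these compounds, the one new step beyond the scatter is the hydrogen in place of the second chloro of compound 2 (a 2.1-fold higher number from compound 2 to compound 4 (0.33 log units; beyond the scatter)), so the modest separation of compound 2 goes with that second chloro and not with the chloro that it shares with compound 4, and no measurement at hand accounts for any of these steps.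

The compounds shown leave open whether the second chloro would give the same step on its own, without the chloro para to a large group. They also leave open whether an amine, a carboxylic acid or a longer alkoxy chain at this place would move the number beyond the scatter at all.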